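Ethoxy to methylamino on the carbonyl carbon

A few compounds are considered here, and "the series" means these few. Any claim that something is new, unique, unknown or untested is made for them only; others in the source may bear on it.

compound 1 `CCOC(=O)/C=C/c1ccncc1-c1ccc2c(cnn2C)c1`: 5030 nM
compound 2 `CNC(=O)/C=C/c1ccncc1-c1ccc2cc[nH]c2c1`: 7840 nM
compound 3 `O=C(O)/C=C/c1ccncc1-c1ccc2[nH]ccc2c1`: > 10000 nM (a limit)

In a functional assay on A549 cells (Homo sapiens) for inhibition, read by sulforhodamine B assay, with a stated time of 72 h (a higher number here means a weaker inhibitor of growth, a lower number a stronger inhibitor of growth), compound 1 gives 5030 nM, which lies within the scatter of compound 2 at 7840 nM. The entry for compound 3 is a limit, not a number. Compound 4 `CNC(=O)/C=C/c1ccncc1-c1ccc2c(cnn2C)c1` carries methylamino in place of ethoxy on a carbonyl carbon. Among the compounds with values here, no measured pair isolates this change. Compound 2 also bears 2-(methylcarbamoyl)ethenyl, on a different core, and stands at 7840 nM, so no change beyond the scatter is expected in this assay. The estimated step is a 1.3-fold higher number from compound 1 to compound 4 (0.11 log units; within the scatter). The expected value for compound 4 is 6500 nM, with an estimated range of 2500 nM to 10000 nM.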

Compound 4, concentration for 50% growth inhibition: > 10000 nM
Compound 4: a limit, no number; the forecaster's own chance of this, stated with the estimate: 20%; at least 1.5-fold (0.18 log units) between middle value and limit.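

Within the data shown here, this pair gives the first reading of a single change on this carbonyl carbon, with the core held constant: an at least 1.9-fold higher number from compound 1 to compound 4 (0.29 log units; that floor lies within the scatter) in this assay. Compound 4 gives > 10000 nM, which is a limit, so methylamino does not yield a number on the core of compound 1, and the full size of the step cannot be read. The floor of the step is set by the assay's ceiling: the limit of > 10000 nM in this assay, at which 2 of the 4 values shown sit.

Still open, as far as these compounds go, is whether a longer alkoxy chain such as propoxy, or dimethylamino, on this carbonyl carbon would give a number under that limit.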